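A few compounds are considered here, and "the series" means these few. Any claim that something is new, unique, unknown or untested is made for them only; others in the source may bear on it.

Measured so far: in a functional assay on MDA-MB-231 cells (Homo sapiens) for antiproliferative activity, read by MTT assay, with a stated time of 72 h (on this read-out higher numbers stand for weaker inhibition and lower numbers for stronger inhibition), compound 1, `NS(=O)(=O)c1ccc(NC(=O)Nc2cccc(-c3nc(-c4ccc(NC(=O)c5cccnc5)cc4Cl)no3)c2)cc1`, gives only a limit, > 10000 nM. Compound 2, `O=C(Nc1cccc(-c2nc(-c3ccc(NC(=O)c4cccnc4)cc3Cl)no2)c1)Nc1cccc(C(F)(F)F)c1`, gives 1900 nM. Compound 3, `CS(=O)(=O)Nc1ccc(NC(=O)Nc2cccc(-c3nc(-c4ccc(NC(=O)c5cccnc5)cc4Cl)no3)c2)cc1Br`, gives 700 nM.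

Compound 3 therefore holds the lowest of the two numbers reported; the nearest number is a 2.7-fold lower number from compound 2 to compound 3 (0.43 log units; beyond the scatter). Compound 4, `CC(=O)Nc1ccc(NC(=O)Nc2cccc(-c3nc(-c4ccc(NC(=O)c5cccnc5)cc4Cl)no3)c2)cc1Cl`, differs from compound 3 in one place: 4-acetamido-3-chlorophenyl in place of 3-bromo-4-(methanesulfonamido)phenyl on an amide-type nitrogen. Every measured step changes the same group on that amide-type nitrogen: an at least 5.2-fold lower number from compound 1 to compound 2 (0.72 log units; beyond the scatter), an at least 14-fold lower number from compound 1 to compound 3 (1.15 log units; beyond the scatter) and a 2.7-fold lower number from compound 2 to compound 3 (0.43 log units; beyond the scatter). Compound 4 keeps a halogen and an amide-type nitrogen substituent on that ring, as compound 3 does, so only a small step is expected in this assay, if any beyond the scatter. Compound 4 is estimated at 900 nM, between 300 nM and 3000 nM, an expected step of a 1.3-fold higher number from compound 3 to compound 4 (0.11 log units; within the scatter).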

Compound 4, half-maximal inhibitory concentration: > 10000 nM
Compound 4 ended at the assay's limit; the forecaster's own chance of this, stated with the estimate: 5%; middle value at least 11-fold (1.04 log units) from the limit.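

In this assay, keeping a halogen and a nitrogen-linked substituent on this ring does not preserve activity: 4-acetamido-3-chlorophenyl in place of 3-bromo-4-(methanesulfonamido)phenyl gives an at least 14-fold higher number from compound 3 to compound 4 (1.15 log units; beyond the scatter). The same group also compares poorly with 3-(trifluoromethyl)phenyl, giving an at least 5.2-fold higher number from compound 2 to compound 4 (0.72 log units; beyond the scatter). The value of compound 4 is a limit, so its step from compound 1 cannot be read: the limit of > 10000 nM in this assay, at which 2 of the 4 values shown sit.

Compound 4 differs from compound 3 in both the halogen and the nitrogen-linked substituent, so which change accounts for the step remains open. Also open, on these data alone, is how 3-bromo-4-acetamidophenyl, or a plain amine on this ring, would behave.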